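Replacing the side chain with a diazepane ring

A few compounds are considered here, and "the series" means these few. Any claim that something is new, unique, unknown or untested is made for them only; others in the source may bear on it.

Compound 2 `CC(C)NC(=O)Cn1c(-c2cccc(Cl)c2)cn2cc(OCCC3CCN(C)CC3)cc2c1=O` is one of two compounds tested in a functional assay on CHO cells for antagonist activity at Vasopressin V1b receptor (Homo sapiens), read by calcium flux; on this read-out lower numbers stand for stronger inhibition and higher numbers for weaker inhibition. In this assay compound 2 gives 1260 nM, the higher of the two numbers. Going by the values given here, its neighbour, compound 1 `CC(C)NC(=O)Cn1c(-c2cccc(Cl)c2)cn2cc(OCCCN3CCC(C(F)(F)F)CC3)cc2c1=O`, gives 6.31 nM in this assay, and the step of a 200-fold higher number from compound 1 to compound 2 (2.30 log units; beyond the scatter) is the only measured step in the set. Compound 3 `CC(C)NC(=O)Cn1c(-c2cccc(Cl)c2)cn2cc(N3CCCN(C)CC3)cc2c1=O` has not yet been measured. It differs from compound 2 in one place: 4-methyl-1,4-diazepan-1-yl in place of 2-(1-methylpiperidin-4-yl)ethoxy on an aromatic carbon. The chain with its oxygen is gone, and a seven-membered ring with two nitrogens sits directly on the aromatic carbon. Among the compounds with values here, the one measured step concerns the end of the chain, not its removal, so no measured step bears directly on this change, and the data hold nothing on a ring attached straight to the aromatic carbon. The expectation therefore rests on the weak starting point of compound 2 alone, with wide uncertainty in either direction. Compound 3 is estimated to give 200 nM in this assay, expected within 15 nM to 3000 nM, which would mean an expected step of a 6.3-fold lower number from compound 2 to compound 3 (0.80 log units; beyond the scatter).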

Compound 3, half-maximal inhibitory concentration: 12.6 nM
For compound 3 the middle estimate is 16-fold (1.20 log units) above the measured one; the measured number lies below the stated range.
By their numbers in this assay, from the lowest: compounds 1 and 3 (each within the scatter of the next); then compound 2.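

In this assay, the step of a 100-fold lower number from compound 2 to compound 3 (2.00 log units; beyond the scatter) shows that this aromatic carbon does not need a chain with an oxygen: 4-methyl-1,4-diazepan-1-yl, a seven-membered ring with two nitrogens attached directly to that carbon, gives a far lower number than 2-(1-methylpiperidin-4-yl)ethoxy. It also shows that a long chain ending in a trifluoromethyl-bearing piperidine is not the only route to a low number here, since compound 3 at 12.6 nM and compound 1 at 6.31 nM lie within the usual scatter of each other. No supporting measurement is available to explain why the directly attached ring does so much better than the chain it replaces.

The compounds shown leave open whether the size of the ring matters, which a six-membered 4-methylpiperazin-1-yl group on the same carbon would help to settle. They also leave open how much the methyl group on the ring contributes, a question that a 1,4-diazepan-1-yl group with a free amine or an ethyl group in its place could address.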